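The source may hold more compounds than are shown below. What is called first, only, known or untested is meant among the compounds shown, and "the series" means these compounds.

Within the data shown here, compound 2 `CCOC(=O)c1c(-c2cc3ccccc3oc2=O)nn(-c2cccc(Cl)c2)c1C(=O)OCC` gives 22000 nM in a functional assay on HeLa cells (Homo sapiens) for cytotoxicity, read by MTT assay, with a stated time of 48 h (on this read-out higher numbers stand for weaker inhibition and lower numbers for stronger inhibition), the lowest of the two numbers so far; compound 1 `CCOC(=O)c1c(-c2cc3ccccc3oc2=O)nn(-c2ccc(C)c(C)c2)c1C(=O)OCC` gives 50000 nM, and the step of a 2.3-fold lower number from compound 1 to compound 2 (0.36 log units; beyond the scatter) is the only one measured. Compound 3 `CCOC(=O)c1c(-c2cc3cc(OC)ccc3oc2=O)nn(-c2cccc(Cl)c2)c1C(=O)OCC` differs from compound 2 by methoxy in place of hydrogen on an aromatic carbon. Among the measured compounds shown here, the step from compound 1 to compound 2 concerns the group on the aromatic nitrogen, not the fused ring, so no measured step bears on this change. With nothing to go on, no step beyond the scatter is expected: no change at the digits printed from compound 2 to compound 3 (within the scatter). Compound 3 is therefore estimated at 22000 nM, within 8000 nM to 60000 nM.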

Compound 3, half-maximal inhibitory concentration: 160000 nM
Beside the measured number, compound 3's estimate is 7.3-fold (0.86 log units) below it, and the stated range ends below it.
By their numbers in this assay, from the lowest: compound 2; then compound 1; then compound 3.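

In this assay methoxy in place of hydrogen on an aromatic carbon of the fused system gives a 7.3-fold higher number from compound 2 to compound 3 (0.86 log units; beyond the scatter) and so moves toward weaker inhibition. The fused system therefore responds to substitution, whereas the earlier pair showed a change only in the group on the aromatic nitrogen. No measured information explains this step.

On these data alone, whether hydroxy or an amine on this same carbon would also weaken inhibition remains open. Also open, as far as these compounds go, is whether methoxy would have a similar effect with 3,4-dimethylphenyl on the aromatic nitrogen.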